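The source may hold more compounds than are shown below. What is called first, only, known or untested is meant among the compounds shown, and "the series" means these compounds.

Compound 1 `CC(c1ccc2oc(-c3ccccc3)cc2c1)N(O)C(=O)c1ccco1`: 40 nM
Compound 2 `CC(=O)OCC(=O)N(O)C(C)c1ccc2oc(-c3ccccc3)cc2c1`: 160 nM
Compound 3 `CCOC(=O)CCC(=O)N(O)C(C)c1ccc2oc(-c3ccccc3)cc2c1`: 50 nM

All three were measured in an assay on RBL cells for inhibition of Polyunsaturated fatty acid 5-lipoxygenase (Rattus norvegicus); a higher number here means a weaker inhibitor, a lower number a stronger inhibitor. Compound 3 stands second highest of the three numbers; its nearest neighbour is compound 1, a 1.3-fold higher number from compound 1 to compound 3 (0.10 log units; within the scatter), and its furthest is compound 2, a 3.2-fold lower number from compound 2 to compound 3 (0.51 log units; beyond the scatter). Compound 4 `COC(=O)CCCC(=O)N(O)C(C)c1ccc2oc(-c3ccccc3)cc2c1` differs from compound 3 by (methoxycarbonyl)methyl in place of ethoxycarbonyl on a saturated chain carbon, two bonds along the chain from a carbonyl carbon. Among the measured compounds shown here, no measured step alters the chain between the carbonyl and the ester in this way. The steps that touch the same place are a 1.3-fold higher number from compound 1 to compound 3 (0.10 log units; within the scatter), within the scatter, and a 3.2-fold lower number from compound 2 to compound 3 (0.51 log units; beyond the scatter), modest. Both ester-bearing chains sit close to compound 1, so for compound 4 a step within the scatter is expected, a 1.2-fold higher number from compound 3 to compound 4 (0.08 log units; within the scatter). Compound 4 is estimated at 60 nM, with a range of 25 nM to 150 nM.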

Compound 4, half-maximal inhibitory concentration: 60 nM
Compound 4: middle estimate and measured number agree at the digits printed, within the range that was stated.
By their numbers in this assay, from the lowest: compounds 1, 3 and 4 (each within the scatter of the next); then compound 2.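

The same atoms joined differently, 2-(ethoxycarbonyl)ethyl against 3-(methoxycarbonyl)propyl on the carbonyl carbon, give no separable number in this assay (a 1.2-fold higher number from compound 3 to compound 4 (0.08 log units; within the scatter)). The longer chain with the methyl ester also stays level with furan-2-yl on that carbon (a 1.5-fold higher number from compound 1 to compound 4 (0.18 log units; within the scatter)), while acetoxymethyl remains apart (a 2.7-fold lower number from compound 2 to compound 4 (0.43 log units; beyond the scatter)). This position therefore accepts the ester in either arrangement shown by compound 3 and compound 4.

Nothing in the data explains why these groups read alike. From the compounds shown here alone, whether a carboxylic acid in place of the ester, or a still longer chain, stays level with compound 4 remains open.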